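The compounds below may be only part of what the source reports. "The series", "measured", "known", "first", "only" and "open" are said of these compounds alone.

Series on the shared core of compound 1 `CCOC1=C(/C(C)=N/OCC(=O)Nc2ccccc2)N(C)S(=O)(=O)c2ccccc21`, varied only at the group on the amide-type nitrogen. In a functional assay on THP-1 cells (Homo sapiens) for inhibition, read by ELISA, with stated times of 2 h and 48 h (a higher number here means a weaker inhibitor, a lower number a stronger inhibitor), compound 1 gives > 20000 nM, which is a limit of the assay and not a number. Compound 2 `CCOC1=C(/C(C)=N/OCC(=O)Nc2cccc(OC)c2)N(C)S(=O)(=O)c2ccccc21` carries methoxy in place of hydrogen on an aromatic carbon. In this assay compound 2 gives > 20000 nM, again a limit. Compound 3 `CCOC1=C(/C(C)=N/OCC(=O)Nc2ccc(OC)cc2)N(C)S(=O)(=O)c2ccccc21` likewise carries methoxy in place of hydrogen on an aromatic carbon. In this assay compound 3 gives > 20000 nM, also a limit. Going by the values given here, compound 3 thus stands where every value so far sits, at the limit of > 20000 nM in this assay, at which 3 of the 3 values shown sit, and the steps a step that the two limits leave unreadable from compound 1 to compound 2, a step that the two limits leave unreadable from compound 1 to compound 3 and a step that the two limits leave unreadable from compound 2 to compound 3 are all of unreadable size.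

The next change is trifluoromethyl in place of methoxy on an aromatic carbon, giving compound 4 `CCOC1=C(/C(C)=N/OCC(=O)Nc2ccc(C(F)(F)F)cc2)N(C)S(=O)(=O)c2ccccc21`. Among the compounds with values here, no measured step in this assay involves trifluoromethyl; the steps that bear on the position, a step that the two limits leave unreadable from compound 1 to compound 3 and a step that the two limits leave unreadable from compound 2 to compound 3, are both unreadable, so no size or direction can be read for the expected step that the limit leaves unreadable from compound 3 to compound 4, and the expectation is that compound 4 again sits at the limit. Compound 4 is therefore expected to give about 40000 nM, with a range from 10000 nM to 200000 nM.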

Compound 4, half-maximal inhibitory concentration: 16700 nM
The estimate for compound 4 lay 2.4-fold (0.38 log units) above the measured number; low and high end bracket the measured number.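

In this assay, going by these compounds alone, trifluoromethyl on the aromatic carbon para to a large group gives the only number, with compound 4 on scale and the others still at a limit of the assay: the limit of > 20000 nM in this assay, at which 3 of the 4 values shown sit. The change therefore gives a lower bound on the step, read as an at least 1.1-fold lower number from compound 3 to compound 4 (0.07 log units; that floor lies within the scatter), as an at least 1.1-fold lower number from compound 2 to compound 4 (0.07 log units; that floor lies within the scatter) and, with hydrogen as the starting point, as an at least 1.1-fold lower number from compound 1 to compound 4 (0.07 log units; that floor lies within the scatter). Each of these floors lies within the scatter, so the position can now yield a measurable value, but compound 4 cannot be separated from compound 1, compound 2 or compound 3 by more than the scatter, and the steps among those three remain unreadable.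

The compounds shown leave open how far the true values of compound 1, compound 2 and compound 3 lie from that of compound 4, and so whether the trifluoromethyl step is small or large. They also leave open whether a chlorine, a nitrile, an amine or a carboxylic acid at the same place on the aromatic ring would give a number in this assay, and whether trifluoromethyl would do so at the 3-position held by methoxy in compound 2.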